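Trimming the ketone side chain of a receptor modulator

A few compounds are considered here, and "the series" means these few. Any claim that something is new, unique, unknown or untested is made for them only; others in the source may bear on it.

Measured compounds:
compound 1, `Cc1cc(C(=O)O)ccc1OCCCCOc1ccc(C(=O)C(C)C)c(O)c1C`: 234 nM
compound 2, `COc1cc(C(=O)O)ccc1OCCCCOc1ccc(C(=O)C(C)C)c(O)c1C`: 113 nM
compound 3, `Cc1c(OCCCCOc2ccc(C(=O)O)c(Cl)c2)ccc(C(=O)CC(C)C)c1C`: > 10000 nM

Of the compounds shown here, three have been tested in an assay on HEK293 cells for positive allosteric modulation of metabotropic glutamate receptor 2 (Rattus norvegicus), read by thallium flux, with a stated time of 2.5 min; on this read-out lower numbers stand for an effect already at smaller amounts and higher numbers for an effect only at larger amounts of compound. Compound 1, `Cc1cc(C(=O)O)ccc1OCCCCOc1ccc(C(=O)C(C)C)c(O)c1C`, gives 234 nM. Among the measured compounds shown here, compound 2, `COc1cc(C(=O)O)ccc1OCCCCOc1ccc(C(=O)C(C)C)c(O)c1C`, gives 113 nM, the lowest of the two numbers reported, and the only measured step, a 2.1-fold lower number from compound 1 to compound 2 (0.32 log units; beyond the scatter), separates it from compound 1. For compound 3, `Cc1c(OCCCCOc2ccc(C(=O)O)c(Cl)c2)ccc(C(=O)CC(C)C)c1C`, the assay reports only a limit, > 10000 nM, and not a number (the limit of > 10000 nM in this assay, at which 1 of the 3 values shown sits).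

Compound 4, `CCC(=O)c1ccc(OCCCCOc2ccc(C(=O)O)cc2OC)c(C)c1O`, has not yet been measured in this assay. It differs from compound 2 in a single place: hydrogen in place of methyl on a saturated chain carbon bound to a carbonyl carbon and a saturated chain carbon. Cut one bond further out, the same change reads isopropylcarbonyl to propanoyl. For the measured compounds named here, none of the measured steps touches this part of the shared core; the one step between compound 1 and compound 2 concerns a methoxy in place of methyl on an aromatic carbon and says nothing about the ketone side chain. With no guidance from the data on this change, the expected step of a 1.8-fold higher number from compound 2 to compound 4 (0.25 log units; within the scatter) is set close to none beyond the scatter, with a wide range to either side. Compound 4 is therefore estimated at 200 nM, between 60 nM and 700 nM.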

Compound 4, half-maximal effective concentration: 114 nM
Compound 4: middle estimate off by 1.8-fold (0.24 log units), on the high side; measured number inside the range.
By their numbers in this assay, from the lowest: compounds 2 and 4 (each within the scatter of the next); then compound 1. At a limit, above all of these: compound 3.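

In this assay, among the compounds shown here, the change from isopropylcarbonyl to propanoyl brings a 1.0-fold higher number from compound 2 to compound 4 (0.00 log units; within the scatter) and so gives the first reading on the ketone side chain, a part of the shared core that the earlier step did not touch. On the core of compound 2, the methyl that leaves this saturated chain carbon can therefore be replaced by hydrogen with no change beyond the scatter, and an ethyl in place of the isopropyl keeps the number where it was. Nothing in the data shown accounts for why the two side chains read alike.

The compounds shown leave open how far this tolerance reaches, that is, whether an acetyl, a longer chain such as butanoyl, or a cyclopropylcarbonyl group on the same carbonyl carbon would also read alike. On these data alone, it also remains open whether isopropylcarbonyl to propanoyl reads the same with methyl in place of methoxy, as on the core of compound 1, as this change is seen here only with the methoxy present.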